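Hydroxamic-acid chain variation on a shared core

The compounds below may be only part of what the source reports. "The series", "measured", "known", "first", "only" and "open" are said of these compounds alone.

Measured so far:
compound 1 `Nc1ncnc2c1c(-c1cnc3[nH]ccc3c1)nn2CCCCCCC(=O)NO` — 50000 nM
compound 2 `Nc1nc2cc(-c3nn(CC(=O)NO)c4ncnc(N)c34)ccc2o1` — 27700 nM
compound 3 `Nc1nc2cc(-c3nn(CCC(=O)NO)c4ncnc(N)c34)ccc2o1` — > 150000 nM

In a functional assay on A549 cells (Homo sapiens) for inhibition, read by MTT assay, with a stated time of 72 h (a higher number here means a weaker inhibitor, a lower number a stronger inhibitor), compound 1 gives 50000 nM and compound 2 gives 27700 nM. Compound 3 gives only a limit of this assay, > 150000 nM. Within the core shared by compound 2 and compound 3, the one step so far is an at least 5.4-fold higher number from compound 2 to compound 3 (0.73 log units; beyond the scatter), so compound 3 stands at the weak end of the numbers shown, with no value but a limit of > 150000 nM in this assay, at which 1 of the 3 values shown sits, to mark its place.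

Compound 4 `Nc1nc2cc(-c3nn(CCCCCCC(=O)NO)c4ncnc(N)c34)ccc2o1` is the next member of this core. 4-(hydroxycarbamoyl)butyl in place of hydroxycarbamoyl on a saturated chain carbon, two bonds along the chain from an aromatic nitrogen

Among the measured compounds shown here, no measured step covers this change directly. The only compound shown that carries a hydroxycarbamoyl group on a chain of comparable length is compound 1, on a different core, with 50000 nM. On the core shared with compound 3, compound 2 has so far given 27700 nM. Compound 3 has so far given only a limit of this assay. From this the expectation for compound 4 is a number back inside the measurable range, an estimated step of an at least 2.5-fold lower number from compound 3 to compound 4 (0.39 log units; beyond the scatter). Compound 4 is therefore expected near 60000 nM, with a plausible range from 15000 nM to 200000 nM.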

Compound 4, half-maximal inhibitory concentration: 33000 nM
For compound 4 the middle estimate is 1.8-fold (0.26 log units) above the measured one; the measured number falls inside the stated range.
By their numbers in this assay, from the lowest: compounds 2, 4 and 1 (each within the scatter of the next). At a limit, above all of these: compound 3.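

Exchanging hydroxycarbamoyl for 4-(hydroxycarbamoyl)butyl on a saturated chain carbon, two bonds along the chain from an aromatic nitrogen, brings the shared core back into the measurable range, with an at least 4.5-fold lower number from compound 3 to compound 4 (0.65 log units; beyond the scatter) in this assay against a limit for compound 3. The step of a 1.2-fold higher number from compound 2 to compound 4 (0.08 log units; within the scatter) shows that chain length on this core does not act in one direction, and compound 3 alone goes against the agreement of the other two. With the chain held constant, the change of aromatic group gives a 1.5-fold lower number from compound 1 to compound 4 (0.18 log units; within the scatter) and so no readable separation.

Still open, from the compounds shown here alone, is whether a longer chain, or a carboxylic acid or a primary amide at the chain end, would move the number on this core. Nothing shown gives a cause for these steps.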